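The source may report more compounds than this note shows. Statements on the series, on what has been measured and on what is new or still open speak of the compounds shown alone.

Within the data shown here, in a functional assay on IMR-32 cells (Homo sapiens) for antiproliferative activity, read by MTT assay (on this read-out higher numbers stand for weaker inhibition and lower numbers for stronger inhibition), compound 1 (`CC(=O)c1ccc(-n2cc(COc3ccc(/C=C/C(=O)c4ccc5c(c4O)CCC(C)(C)O5)cc3)nn2)cc1`) gives 89600 nM as the higher of the two numbers measured so far. Compound 2 (`CCCCCCCCn1cc(COc2ccc(/C=C/C(=O)c3cc4c(cc3O)OC(C)(C)CC4)cc2)nn1`) gives 7090 nM in the same test, and the gap between the two lies beyond the scatter. Compound 3 (`CCCCCn1cc(COc2ccc(/C=C/C(=O)c3ccc4c(c3O)CCC(C)(C)O4)cc2)nn1`) has not yet been measured. It differs from compound 1 by pentyl in place of 4-acetylphenyl on an aromatic nitrogen of a five-membered aromatic ring with 3 nitrogen, a change counted as pentyl in place of 4-acetylphenyl on an aromatic nitrogen for the two structures. Among the measured compounds shown here, no measured step isolates a single change, so the expectation rests on thin evidence. Compound 2 also lacks the 4-acetylphenyl and gives 7090 nM as its number, but its core is not the same as the core of compound 1, so it is only a loose guide. In this assay the expected move is a 4.5-fold lower number from compound 1 to compound 3 (0.65 log units; beyond the scatter) as an estimated shift toward a lower number, modestly beyond the scatter. For compound 3 the estimate is 20000 nM as the expected middle, with an expected range from 6000 nM to 70000 nM for its measurement.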

Compound 3, half-maximal inhibitory concentration: "not active" (no number reported)
Nothing numeric was reported for compound 3; no gap can be computed for the estimate.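

In this assay, among these compounds, compound 3 is reported only as "not active", without a number, so no step from compound 1 to compound 3 can be read. Nothing in the data shown accounts for this result. The compounds shown leave open how pentyl in place of 4-acetylphenyl on the shared core acts on a numeric scale.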